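Urea series: aryl substituent change on whole-organism read-out

This account rests on a few compounds, and the source may have more. Where it says the series, first, only, none or still open, it means among the compounds named here.

Measured so far:
compound 1 `CC(C)c1cccc(NC(=O)N[C@@H](C)c2ccccc2)c1`: 95%
compound 2 `COc1cccc(NC(=O)N[C@@H](C)c2ccccc2)c1`: 101%

In an ADME assay on the whole organism with Oryza sativa as the target, tested at 0.1 uM (on this read-out higher numbers stand for a weaker effect at the one concentration tested and lower numbers for a stronger effect), compound 1 gives 95% and compound 2 gives 101%. Among the compounds with values here, compound 2 holds the higher of the two numbers, with compound 1 as its only neighbour, but the two lie within the scatter of each other, so no order can be read from them. Within the data shown here, the single measured step, a number 6 percentage points higher from compound 1 to compound 2 (within the scatter), stays within the scatter.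

Compound 3 `C[C@H](NC(=O)Nc1cccc(Br)c1)c1ccccc1` is not yet measured. It differs from compound 2 as follows: bromo in place of methoxy on an aromatic carbon. Among the measured compounds shown here, no measured step exchanges methoxy for bromo. For the measured compounds named here, the one step at hand, a number 6 percentage points higher from compound 1 to compound 2 (within the scatter), bears only indirectly, in that it shows an exchange of the substituent on this aromatic carbon leaving the read-out where it stood. On that basis no step beyond the scatter is expected in this assay. Compound 3 is expected to show a number 3 percentage points lower from compound 2 to compound 3 (within the scatter). Compound 3 is therefore estimated at 98% in this assay, with a range from 85% to 110%; a single step outside this range would not contradict the sparse data.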

Compound 3, a percentage reported as activity, at one concentration (the size of the read-out at that concentration, not a potency): 100%
The estimate for compound 3 lay 2 percentage points below the measured number, within the range that was stated.
By their numbers in this assay, from the lowest: compounds 1, 3 and 2 (each within the scatter of the next).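

In this assay the result reads a number 1 percentage points lower from compound 2 to compound 3 (within the scatter) for bromo in place of methoxy on this aromatic carbon and a number 5 percentage points higher from compound 1 to compound 3 (within the scatter) for bromo in place of isopropyl. The earlier pair covered only isopropyl and methoxy, whereas the set now also holds bromo, a single heavy atom with no hydrogen-bond acceptor, and the numbers for all three substituents still lie within the scatter of one another, so no order among them can be read. Nothing measured alongside these numbers bears on the result.

The compounds shown leave open whether this aromatic carbon tolerates any substituent in this assay or whether a group of another kind, such as an amine, a carboxylic acid or a longer chain, would take the number beyond the scatter. They also leave open whether the same flat picture would hold at a concentration other than the one tested, since a single concentration gives the size of the read-out and not a potency.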